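Formyl in place of iodo: compound 3 to compound 4

The source may report more compounds than this note shows. Statements on the series, on what has been measured and on what is new or still open speak of the compounds shown alone.

Of the compounds shown here, three have been measured, and in each case only a limit is reached. Compound 1 `O=c1cc(I)n([C@@H]2O[C@H](CO)[C@@H](O)[C@H]2O)c(=O)[nH]1` gives in a functional assay on MCF7 cells (Homo sapiens) for antiproliferative activity, read by WST assay, with a stated time of 3 days (on this read-out lower numbers stand for stronger inhibition and higher numbers for weaker inhibition), a value of > 50000 nM, which is a limit of the assay and not a number. Compound 2 `COC(=O)c1cc(=O)[nH]c(=O)n1[C@@H]1O[C@H](CO)[C@@H](O)[C@H]1O` gives in this assay a value of > 50000 nM, likewise a limit. Compound 3 `O=c1[nH]c(=O)n([C@@H]2O[C@H](CO)[C@@H](O)[C@H]2O)c(I)c1F` gives in this assay a value of > 50000 nM, again only a limit. Accordingly the two steps measured so far, a step that the two limits leave unreadable from compound 1 to compound 2 and a step that the two limits leave unreadable from compound 1 to compound 3, cannot be sized, since all three values sit at the limit of > 50000 nM in this assay, at which 3 of the 3 values shown sit. Compound 3 therefore stands at the same limit as the other two, with no number to distinguish it.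

Compound 4 `O=Cc1c(F)c(=O)[nH]c(=O)n1[C@@H]1O[C@H](CO)[C@@H](O)[C@H]1O` differs from compound 3 by formyl in place of iodo on an aromatic carbon. Within the data shown here, no measured step bears directly on this change, and the two steps that exist are unreadable. The expected step that the limit leaves unreadable from compound 3 to compound 4 is therefore nothing beyond the scatter, and compound 4 is expected to remain at or near the limit, with an estimate of 60000 nM and a range from 15000 nM to 200000 nM, most probably reported again as a limit only.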

Compound 4, half-maximal inhibitory concentration: 23700 nM
Beside the measured number, compound 4's estimate is 2.5-fold (0.40 log units) above it; low and high end bracket the measured number.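

Formyl in place of iodo, on the aromatic carbon next to the ring nitrogen and ortho to a fluoro group, gives an at least 2.1-fold lower number from compound 3 to compound 4 (0.32 log units; beyond the scatter) in this assay. Among these compounds, this position therefore responds to a change of group, and compound 4 carries the first actual number. The earlier steps cannot be read, and the other three compounds stop at a limit of the assay: the limit of > 50000 nM in this assay, at which 3 of the 4 values shown sit.

What the fluoro group contributes alongside formyl remains open, since no pair shown isolates it in the presence of formyl. Also open, going by these compounds, is whether a carboxylic acid, a hydroxymethyl group or an amine at this position would lower the number further or return it to the limit.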